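Swapping Fluoro for Methoxy: From Compound 2 to Compound 3

The source may report more compounds than this note shows. Statements on the series, on what has been measured and on what is new or still open speak of the compounds shown alone.

Measured so far:
compound 1, `COc1ccc(C(=O)/C=C/c2ccc(Br)cc2)cc1`, 25100 nM
compound 2, `COc1ccc(C(/C=C/c2ccc(F)cc2)=N/O)cc1`, 11000 nM

Two compounds have been run in a functional assay (Mus musculus, strain Balb/c) for inhibition, read by ELISA, with a stated time of 72 h; on this read-out higher numbers stand for weaker inhibition and lower numbers for stronger inhibition. Compound 1 gives 25100 nM, and compound 2 gives 11000 nM. Compound 2 thus holds the lower of the two numbers, with compound 1 standing higher by a gap that lies beyond the usual scatter.

Compound 3, `COc1ccc(/C=C/C(=N\O)c2ccc(OC)cc2)cc1`, is not yet measured. It differs from compound 2 by methoxy in place of fluoro on an aromatic carbon. Among the measured compounds shown here, no measured pair isolates this kind of change, so there is nothing in the data to set its direction. The step from compound 2 to compound 3 in this assay is expected to be small, a 1.1-fold higher number from compound 2 to compound 3 (0.04 log units; within the scatter), most likely within the scatter. Compound 3 is therefore estimated at about 12000 nM, in a range from 4000 nM to 36000 nM.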

Compound 3, half-maximal inhibitory concentration: 12300 nM
Estimate against measurement, compound 3: 1.0-fold (0.01 log units) below; the measured number falls inside the stated range.
By their numbers in this assay, from the lowest: compounds 2 and 3 (each within the scatter of the next); then compound 1.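

In this assay, the exchange of fluoro for methoxy gives a 1.1-fold higher number from compound 2 to compound 3 (0.05 log units; within the scatter) and provides the first step measured at this aromatic carbon, para to a large group. The position therefore accepts methoxy, with 2 heavy atoms and 1 hydrogen-bond acceptor, in place of fluoro, with 1 heavy atom and no hydrogen-bond acceptor, with no change beyond the scatter. No measurement is available that would explain this result.

This single pair cannot show whether the position stays as undemanding with groups of other kinds, such as an amine, a carboxylic acid or a longer chain. It also leaves open whether the same exchange would give a similar step on a different core.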